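Thienyl for Fluorophenyl on a Shared Core

This account rests on a few compounds, and the source may have more. Where it says the series, first, only, none or still open, it means among the compounds named here.

Measured so far:
Compound 1, `c1cn2cc(-c3ccsc3)nc(-c3ccc4ncn(C5CCCCC5)c4c3)c2n1`: 23.1%
Compound 2, `Fc1ccccc1-c1cn2ccnc2c(-c2ccc3ncn(C4CCCCC4)c3c2)n1`: 22.9%

In a functional assay on UO-31 cells (Homo sapiens) for inhibition, read by sulforhodamine B assay, with a stated time of 48 h, tested at 10 uM (a lower number here means less inhibition, a higher number more inhibition at the concentration tested (going by the name of the read-out)), compound 1 gives 23.1%, and compound 2 gives 22.9%. Among the compounds with values here, these two numbers sit within the scatter of each other, so on the values shown compound 2 cannot be told apart from compound 1; the one measured step, a number 0.2 percentage points lower from compound 1 to compound 2 (within the scatter), is simply noise.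

Compound 3, `c1csc(-c2cn3ccnc3c(-c3ccc4ncn(C5CCCCC5)c4c3)n2)c1`, differs from compound 2 in one place: thiophen-2-yl in place of 2-fluorophenyl on an aromatic carbon.

Within the data shown here, the only measured step that bears on this is a number 0.2 percentage points lower from compound 1 to compound 2 (within the scatter), in which a thiophen-3-yl gave way to a 2-fluorophenyl without any change beyond the scatter. The new change runs the other way, with a thiophen-2-yl entering where the 2-fluorophenyl leaves. Since the earlier exchange of these two kinds of ring left the read-out unchanged, little movement is expected here either, because a number 0.2 percentage points lower from compound 1 to compound 2 (within the scatter) stayed within the scatter.

For compound 3 the expected step is a number 0.1 percentage points higher from compound 2 to compound 3 (within the scatter), that is, none beyond the scatter. Compound 3 is therefore estimated at 23%, with a range from 10% to 36%.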

Compound 3, a percentage reported as inhibition, at one concentration (the size of the read-out at that concentration, not a potency): 10.9%
Compound 3: the middle estimate sits 12.1 percentage points above what was measured; low and high end bracket the measured number.
By their numbers in this assay, from the lowest: compound 3; then compounds 2 and 1 (each within the scatter of the next).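

In this assay, within the data shown here, the thiophen-2-yl change gives a number 12 percentage points lower from compound 2 to compound 3 (beyond the scatter), so this position on the shared core does respond to the group placed on it, which the first pair of compounds gave no sign of. The comparison between the two thiophenes is more telling: thiophen-2-yl in place of thiophen-3-yl gives a number 12.2 percentage points lower from compound 1 to compound 3 (beyond the scatter), so the point at which the same kind of ring is attached matters here, and ring size alone does not sort the series, as compound 1, with its five-membered ring, lies within the scatter of compound 2, with its six-membered ring. No measurement offered here explains why the thiophen-2-yl compound stands apart.

The compounds shown leave open whether this position accepts only aromatic rings, as all three compounds carry one there, and a saturated morpholine, a simple amine or a carboxylic acid in that place would test this. They also leave open whether the thiophen-2-yl result is particular to that ring or would be shared by a close relative such as furan-2-yl or pyridin-2-yl.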